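The source may hold more compounds than are shown below. What is called first, only, known or untested is meant among the compounds shown, and "the series" means these compounds.

Compound 2 `CCCO/N=C/c1c(N)ncnc1Oc1ccc2[nH]c(C)cc2c1F` gives 40 nM in a functional assay on HeLa cells (Homo sapiens) for antiproliferative activity (on this read-out higher numbers stand for weaker inhibition and lower numbers for stronger inhibition), the second highest of the three numbers recorded. Its nearest neighbour is compound 1 `CCO/N=C/c1c(N)ncnc1Oc1ccc2[nH]c(C)cc2c1F`, which in this assay gives 32 nM; its furthest is compound 3 `CO/N=C/c1c(N)ncnc1Oc1ccc2cccnc2c1`, which gives 1820 nM. For the measured compounds named here, the only single-point step measured, a 1.3-fold higher number from compound 1 to compound 2 (0.10 log units; within the scatter), lay within the scatter. Compound 4 `Cc1cc2c(F)c(Oc3ncnc(N)c3/C=N/OCCCO)ccc2[nH]1` differs from compound 2 by hydroxy in place of hydrogen on a saturated chain carbon, three bonds along the chain from an oxygen. Going by the values given here, that step also touches the chain hanging from the oxime, so the step from compound 1 to compound 2 bears on it; no measured step, however, adds a hydroxy. Compound 4 is therefore expected to show a step of a 1.3-fold higher number from compound 2 to compound 4 (0.10 log units; within the scatter) in this assay, no larger than the scatter. Compound 4 is estimated at 50 nM, between 18 nM and 140 nM.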

Compound 4, half-maximal inhibitory concentration: 362 nM
Compound 4: the middle estimate sits 7.2-fold (0.86 log units) below what was measured; measured number above the stated range.
By their numbers in this assay, from the lowest: compounds 1 and 2 (each within the scatter of the next); then compound 4; then compound 3.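

Going from propyl to 3-hydroxypropyl in this assay gives a 9.1-fold higher number from compound 2 to compound 4 (0.96 log units; beyond the scatter) and so shows that this chain is not indifferent to every change, although the added methyl of the earlier step stayed within the scatter. Hydroxy on a saturated chain carbon, three bonds along the chain from an oxygen, thus counts for more here than that methyl did. Read from the shorter chain, the change gives an 11-fold higher number from compound 1 to compound 4 (1.05 log units; beyond the scatter) and points the same way.

From the compounds shown here alone, whether a methoxy, an amine or a carboxylic acid at that carbon, or a longer chain carrying hydroxy, would give a similar step stays open. No measurement at hand accounts for the step.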